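A few compounds are considered here, and "the series" means these few. Any claim that something is new, unique, unknown or untested is made for them only; others in the source may bear on it.

In an ADME assay on Vero cells (Chlorocebus sabaeus) for cytotoxicity, read by MTT assay, with a stated time of 24 h (on this read-out higher numbers stand for lower toxicity in this test and lower numbers for higher toxicity in this test), compound 3 (`COc1ccc(CN(Cc2ccc(OC(F)(F)F)cc2)c2ccc3nc(N)nc(N)c3c2)cc1`) gives > 200000 nM as a limit of the assay and not a number. Compound 1 (`Nc1nc(N)c2cc(N(Cc3ccc(OC(F)(F)F)cc3)Cc3ccc(OC(F)(F)F)cc3)ccc2n1`) likewise gives > 200000 nM as a limit. Compound 2 (`COc1ccc(CNc2ccc3nc(N)nc(N)c3c2)cc1`) gives a measured number of 147000 nM in this assay. Compound 4 (`COc1ccc(CN(Cc2ccc(OC)cc2)c2ccc3nc(N)nc(N)c3c2)cc1`) differs from compound 3 by methyl in place of trifluoromethyl on an oxygen on an aromatic ring with methyl in place of trifluoromethyl on an oxygen on an aromatic ring. Going by the values given here, the only measured step of this kind is a step that the two limits leave unreadable from compound 1 to compound 3 and it gives no size to carry over. The other guide is the limit of > 200000 nM in this assay, at which 2 of the 3 values shown sit, and it too holds no number. In this assay the expected result is a number no higher from compound 3 to compound 4 (the limit leaves the size open) with no step beyond the scatter expected in either direction. For compound 4 the estimate is 200000 nM with an expected range from 100000 nM to 400000 nM as its ends.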

Compound 4, half-maximal cytotoxic concentration: > 200000 nM
Compound 4 was reported as a limit (the forecaster's own chance of this, stated with the estimate: 60%); the middle value sits exactly at the limit.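

In this assay compound 4 gives > 200000 nM, a limit of the assay and not a number. A second replacement of trifluoromethoxy by methoxy thus leaves the read-out at the limit, and steps between such limits cannot be read. The one readable step is an at least 1.3-fold higher number from compound 2 to compound 4 (0.13 log units; that floor lies within the scatter), and the limit remains the main guide: the limit of > 200000 nM in this assay, at which 3 of the 4 values shown sit.

Still open, as far as these compounds go, is whether an amine or a carboxylic acid in place of methoxy would bring the read-out down to a number. From the compounds shown here alone, how far beyond the limit compound 1, compound 3 and compound 4 truly lie also stays unknown.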